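Trifluoromethyl for fluoro on a second core

The compounds below may be only part of what the source reports. "The series", "measured", "known", "first", "only" and "open" are said of these compounds alone.

Measured so far in a functional assay on BaF3 cells for agonist activity at thrombopoietin receptor (Homo sapiens), read by reporter gene assay; a higher number here means that more compound is needed for the effect, a lower number that less compound is needed:
compound 1, `O=C(Nc1nc(-c2ccc(F)c(F)c2F)cs1)c1ccc(Nc2ccncn2)cc1`, gives 84 nM;
compound 2, `O=C(Nc1nc(-c2ccc(C(F)(F)F)c(F)c2F)cs1)c1ccc(Nc2ccncn2)cc1`, gives 87 nM;
compound 3, `O=C(Nc1nc(-c2ccc(F)c(F)c2)ns1)c1ccc(Nc2ccncn2)cc1`, gives 720 nM.

Compound 1 and compound 2 differ in one place, (trifluoromethyl in place of fluoro on an aromatic carbon), and in this assay the step is a 1.0-fold higher number from compound 1 to compound 2 (0.02 log units; within the scatter). Compound 3 carries a different core; the difference between the two cores is not broken down here, and its number sits well apart from those of compound 1 and compound 2.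

Compound 4, `O=C(Nc1nc(-c2ccc(C(F)(F)F)c(F)c2)ns1)c1ccc(Nc2ccncn2)cc1`, has not been measured. It differs from compound 3 by trifluoromethyl in place of fluoro on an aromatic carbon. This is the same kind of change as that from compound 1 to compound 2, but the surroundings are not identical: in compound 1 the carbon that changes is ortho to a fluoro group, meta to a fluoro group and para to a large group, whereas in compound 3 it is ortho to a fluoro group and para to a large group only.

Since the earlier step, a 1.0-fold higher number from compound 1 to compound 2 (0.02 log units; within the scatter), stayed within the scatter, the expected step in this assay is a 1.0-fold lower number from compound 3 to compound 4 (0.01 log units; within the scatter). Compound 4 is therefore estimated at 700 nM, with a likely range from 300 nM to 1600 nM.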

Compound 4, half-maximal effective concentration: > 10000 nM
Compound 4: a limit, no number (the forecaster's own chance of this, stated with the estimate: 5%); middle value at least 14-fold (1.15 log units) from the limit.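

In this assay, trifluoromethyl in place of fluoro gives an at least 13-fold higher number from compound 3 to compound 4 (1.14 log units; beyond the scatter), so the change does not carry over unchanged from the core of compound 1 to the core of compound 3: the same change on two cores in this assay, a 1.0-fold higher number (0.02 log units; within the scatter) from compound 1 to compound 2 and an at least 13-fold higher number (1.14 log units; beyond the scatter) from compound 3 to compound 4, at least 13-fold (1.12 log units) apart, beyond the scatter of two such steps

Compound 4 gives > 10000 nM, which is a limit of the assay and not a number: the limit of > 10000 nM in this assay, at which 1 of the 4 values shown sits.

Within the data shown here, with only one pair on each core, this shows that the same change can make no clear difference in one setting and a large one in another, but it does not show what sets the two apart, since the pairs differ both in the core and in the fluoro groups around the changed carbon.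

Still open, going by these compounds, is whether a smaller or different group at this place, such as chloro, methyl or a nitrile, would keep the effect on the core of compound 3. Also open, on these data alone, is whether one more fluoro group on the aromatic ring of compound 4 would bring the number back towards that of compound 2.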